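The compounds below may be only part of what the source reports. "The series", "measured", "known", "first", "only" and "open" are said of these compounds alone.

Compound 1 `O=C1N/C(=N/c2csc(-c3ccc(Cl)cc3)c2)S/C1=C\c1ccccc1` in a functional assay on HT-29 cells (Homo sapiens) for cytotoxicity, read by MTT assay, with a stated time of 72 h (on this read-out lower numbers stand for stronger inhibition and higher numbers for weaker inhibition), gives 10500 nM. Compound 2 `O=C1N/C(=N/c2csc(-c3ccc(Cl)cc3)c2)S/C1=C\c1ccc(O)cc1` carries a hydroxy in place of a hydrogen on an aromatic carbon. Compound 2 in this assay gives only a limit, > 50000 nM. The step of an at least 4.7-fold higher number from compound 1 to compound 2 (0.67 log units; beyond the scatter) is thus open-ended, set by the limit of > 50000 nM in this assay, at which 1 of the 2 values shown sits. Compound 3 `O=C1N/C(=N/c2csc(-c3ccc(Cl)cc3)c2)S/C1=C\c1ccc2ccccc2c1` differs from compound 2 by naphthalen-2-yl in place of 4-hydroxyphenyl on a double-bonded chain carbon bound to a double-bonded ring carbon. Within the data shown here, the single measured step bears on this change in reverse: the hydroxy that cost potency is removed, while the second ring is untested. Compound 3 is expected to regain roughly what the step of an at least 4.7-fold higher number from compound 1 to compound 2 (0.67 log units; beyond the scatter) lost. Compound 3 is estimated at 8000 nM, range 2500 nM to 30000 nM, an expected step of an at least 6.2-fold lower number from compound 2 to compound 3 (0.79 log units; beyond the scatter).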

Compound 3, half-maximal inhibitory concentration: 3700 nM
Compound 3: middle estimate off by 2.2-fold (0.33 log units), on the high side, and the stated range covers the measured number.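

In this assay, the double-bonded chain carbon bound to the double-bonded ring carbon takes a larger aromatic group: naphthalen-2-yl in place of phenyl gives a 2.8-fold lower number from compound 1 to compound 3 (0.45 log units; beyond the scatter) and so goes beyond merely losing the hydroxy. Naphthalen-2-yl in place of 4-hydroxyphenyl gives an at least 13-fold lower number from compound 2 to compound 3 (1.13 log units; beyond the scatter) as its step, which is open-ended, as compound 2 gives only a limit: the limit of > 50000 nM in this assay, at which 1 of the 3 values shown sits.

Left open is how a methoxy or an amino group on the phenyl would compare with the hydroxy of compound 2. As far as these compounds go, whether naphthalen-1-yl would match naphthalen-2-yl also remains open.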